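The source may report more compounds than this note shows. Statements on the series, on what has been measured and on what is new or still open speak of the compounds shown alone.

Measured in a physicochemical assay for solubility, read by chemiluminescence, measured as kinetic solubility; a higher number here means a more soluble compound, a lower number a less soluble compound:
- Compound 1 `COc1nn(C)c2ncnc(NS(=O)(=O)c3cccc(Cl)c3Cl)c12`: >= 581000 nM, a limit of the assay
- Compound 2 `CNC(=O)Cn1nc(OC)c2c(NS(=O)(=O)c3cccc(Cl)c3Cl)ncnc21`: >= 509000 nM, a limit of the assay
- Compound 3 `COc1nn(C2COC2)c2ncnc(NS(=O)(=O)c3cccc(Cl)c3Cl)c12`: 142000 nM

Compound 3 is the only one of the three with a true number, and it stands lowest: the data show an at least 4.0-fold lower number from compound 1 to compound 3 (0.61 log units; beyond the scatter) and an at least 3.5-fold lower number from compound 2 to compound 3 (0.55 log units; beyond the scatter). Compound 4 `COc1nn(CCN(C)C)c2ncnc(NS(=O)(=O)c3cccc(Cl)c3Cl)c12` differs from it on the aromatic nitrogen, with 2-(dimethylamino)ethyl in place of oxetan-3-yl on an aromatic nitrogen. The two steps above change the same place, and in both the ringless group gives way to oxetan-3-yl. Neither involves the 2-(dimethylamino)ethyl group, so the read-across is loose. A modest rise is expected on leaving oxetan-3-yl, estimated as a 2.5-fold higher number from compound 3 to compound 4 (0.39 log units; beyond the scatter). Compound 4 is estimated at 350000 nM, with an expected range of 130000 nM to 600000 nM.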

Compound 4, solubility: 358000 nM
Compound 4: the middle estimate sits 1.0-fold (0.01 log units) below what was measured; the range from low to high includes it.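

In this assay a third group on this aromatic nitrogen stands clear of oxetan-3-yl, with a 2.5-fold higher number from compound 3 to compound 4 (0.40 log units; beyond the scatter) for 2-(dimethylamino)ethyl, so among these compounds the lowest number goes with oxetan-3-yl. Compound 4 cannot be ranked against the other two: an at least 1.4-fold lower number from compound 2 to compound 4 (0.15 log units; that floor lies within the scatter) and an at least 1.6-fold lower number from compound 1 to compound 4 (0.21 log units; that floor lies within the scatter) are steps from limits of the assay, and each floor lies within the scatter.

The compounds shown leave open whether the gap follows the dimethylamino group or the loss of the ring. A plain ethyl chain, a carboxylic acid or a morpholine on this nitrogen would bear on that.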